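A few compounds are considered here, and "the series" means these few. Any claim that something is new, unique, unknown or untested is made for them only; others in the source may bear on it.

Of the compounds shown here, three that share one core have been measured in a functional assay on CHO-K1 cells for antagonist activity at melanin-concentrating hormone receptor 1 (Homo sapiens), read by inositol phosphate accumulation, with stated times of 10 min and 45 min; a higher number here means a weaker inhibitor, a lower number a stronger inhibitor. Compound 3 `Cc1nc(N2CCC(O)(C3CC3)CC2)nc2ccc(NC(=O)/C=C/c3ccc(Cl)cc3Cl)cc12` gives 575 nM and stands with the highest number of the three; compound 1 `C/C(=C\C(=O)Nc1ccc2nc(N3CCC(O)(C4CC4)CC3)nc(C)c2c1)c1ccc(Cl)cc1` gives 340 nM, and compound 2 `Cc1nc(N2CCC(O)(C3CC3)CC2)nc2ccc(NC(=O)/C=C/c3ccc(C(F)(F)F)cc3)cc12` gives 83 nM. Compound 4 `COc1ccc(/C=C/C(=O)Nc2ccc3nc(N4CCC(O)(C5CC5)CC4)nc(C)c3c2)cc1` has not yet been measured. The change from compound 3 to compound 4 is 4-methoxyphenyl in place of 2,4-dichlorophenyl on a double-bonded chain carbon bound to a double-bonded chain carbon. For the measured compounds named here, two measured steps bear on it: a 6.9-fold higher number from compound 2 to compound 3 (0.84 log units; beyond the scatter), which exchanges the same group at the same place, and a 1.7-fold higher number from compound 1 to compound 3 (0.23 log units; within the scatter). Only the first of these moves the number beyond the scatter, so a change at this group can matter, yet the gain may not repeat here. The estimated step is a 1.3-fold lower number from compound 3 to compound 4 (0.11 log units; within the scatter). In this assay compound 4 is expected to give 450 nM, within 130 nM to 1500 nM.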

Compound 4, half-maximal inhibitory concentration: 59 nM
Beside the measured number, compound 4's estimate is 7.6-fold (0.88 log units) above it; measured number outside the range, below it.
By their numbers in this assay, from the lowest: compounds 4 and 2 (each within the scatter of the next); then compounds 1 and 3 (each within the scatter of the next).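

In this assay, the exchange of 2,4-dichlorophenyl for 4-methoxyphenyl gives a 9.7-fold lower number from compound 3 to compound 4 (0.99 log units; beyond the scatter), so this position can yield a large change even between groups of equal heavy-atom count. The step of a 1.4-fold lower number from compound 2 to compound 4 (0.15 log units; within the scatter) means that methoxy and trifluoromethyl on the aromatic carbon cannot be told apart here, while the exchange of the whole side group gives a 5.8-fold lower number from compound 1 to compound 4 (0.76 log units; beyond the scatter). Nothing available explains these differences. The compounds shown leave open how an ethoxy group, an amine or a carboxylic acid in place of methoxy on that aromatic carbon would read.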